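Halogen Swap on Two Cores in a Cytotoxicity Assay

The source may report more compounds than this note shows. Statements on the series, on what has been measured and on what is new or still open speak of the compounds shown alone.

Compound 1 `O=C1O/C(=C\Cn2cc(Br)c(=O)[nH]c2=O)C(OCc2ccccc2)=C1OCc1ccccc1` gives 7500 nM in an ADME assay on L1210/0 cells (Mus musculus) for cytotoxicity, with a stated time of 48 h; on this read-out higher numbers stand for weaker inhibition and lower numbers for stronger inhibition.
Compound 2 `O=C1O/C(=C\Cn2cc(Cl)c(=O)[nH]c2=O)C(OCc2ccccc2)=C1OCc1ccccc1` gives 12200 nM in this assay.
Compound 3 `Nc1nc2c(nc(Br)n2COCCO)c(=O)[nH]1` gives > 200000 nM in this assay; this is a limit of the assay, not a number.

Compounds 1 and 2 share one core and differ only in chloro in place of bromo on an aromatic carbon; in this assay that change gave a 1.6-fold higher number from compound 1 to compound 2 (0.21 log units; within the scatter). Compound 3 carries a different core, and how the two cores differ is not broken down here. Compound 4 `Nc1nc2c(nc(Cl)n2COCCO)c(=O)[nH]1` is still to be measured in this assay. It stands to compound 3 as compound 2 stands to compound 1, through the same kind of change, (chloro in place of bromo on an aromatic carbon); the surroundings are not identical, since the carbon now sits on a five-membered aromatic ring with 2 nitrogen, part of a fused or bridged system of two rings, between two ring nitrogen atoms, next to the ring atom that bears a (2-hydroxyethoxy)methyl group, rather than on a six-membered aromatic ring with 2 nitrogen. For compound 3 only the limit of > 200000 nM in this assay, at which 1 of the 3 values shown sits, is known. The step of a 1.6-fold higher number from compound 1 to compound 2 (0.21 log units; within the scatter) stayed within the scatter, and on that the expectation rests. Compound 4 is expected to move little, with an estimated step that the limit leaves unreadable from compound 3 to compound 4. The estimate for compound 4 is 300000 nM, most likely again reported only as a limit.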

Compound 4, half-maximal inhibitory concentration: > 200000 nM
Compound 4 gave a limit, no number; the forecaster's own chance of this, stated with the estimate: 85%; the middle value lies beyond the limit too.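

In this assay compound 4 gives > 200000 nM and this is a limit of the assay, not a number. Within the data shown here, compound 3 gives > 200000 nM and this too is a limit, so no step between these two compounds can be read. The compounds shown leave open what chloro in place of bromo does on the core of compound 3, where the values stop at the limit: the limit of > 200000 nM in this assay, at which 2 of the 4 values shown sit.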